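Swapping Cyano for Fluoro on One Aromatic Carbon

The source may hold more compounds than are shown below. What is called first, only, known or untested is meant among the compounds shown, and "the series" means these compounds.

In a functional assay on the whole organism for activation, with Mus musculus as the target, with a stated time of 60 min (a higher number here means that more compound is needed for the effect, a lower number that less compound is needed), compound 1 `O=C1NC(=O)N(/N=C/c2ccc(-c3ccc(Cl)c(Cl)c3)o2)C1O` needs 109 mg/kg for the effect. Compound 2 `N#Cc1ccc(-c2ccc(/C=N/N3C(=O)NC(=O)C3O)o2)cc1` reads > 1000 mg/kg here, which is a limit of the assay and not a number. Compound 3 `O=C1NC(=O)N(/N=C/c2ccc(-c3ccc(F)cc3)o2)C1O` carries fluoro in place of cyano on an aromatic carbon, para to a large group (fluoro in place of cyano on an aromatic carbon), and is otherwise the same as compound 2. Within the data shown here, no measured step shows the size of this change. In this assay a lower dose, beyond the usual scatter, is expected, resting on compound 1 at 109 mg/kg on the shared core. The expected step of an at least 3.3-fold lower number from compound 2 to compound 3 (0.52 log units; beyond the scatter) is only a rough estimate. For compound 3 the estimate is 300 mg/kg as the middle value, with 90 mg/kg to 900 mg/kg as its range.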

Compound 3, dose for half-maximal effect: > 1000 mg/kg
Compound 3 gave a limit, no number; the forecaster's own chance of this, stated with the estimate: 25%; middle value at least 3.3-fold (0.52 log units) away from the limit.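

Compound 2 and compound 3 both give only a limit in this assay, not a number, so no step between them can be read: the limit of > 1000 mg/kg in this assay, at which 2 of the 3 values shown sit.

As far as these compounds go, whether fluoro in place of cyano changes the dose needed at all stays open.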